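A Dichlorophenyl Swap on the Shared Core

This account rests on a few compounds, and the source may have more. Where it says the series, first, only, none or still open, it means among the compounds named here.

Compound 1 `O=C(Cc1csc2nc(-c3ccc(Br)cc3)cn12)N/N=C/c1ccc(O)cc1` gives 14800 nM in a functional assay on CAKI-1 cells (Homo sapiens) for inhibition, read by sulforhodamine B assay, with a stated time of 48 h; a higher number here means a weaker inhibitor of growth, a lower number a stronger inhibitor of growth
Compound 2 `COc1cccc(OC)c1/C=N/NC(=O)Cc1csc2nc(-c3ccc(Br)cc3)cn12` gives 12600 nM in this assay

Compound 1 and compound 2 lie within the scatter of each other, and no other measured number exists to place compound 2 against. Compound 3 `O=C(Cc1csc2nc(-c3ccc(Br)cc3)cn12)N/N=C/c1ccc(Cl)cc1Cl` differs from compound 2 in one place: 2,4-dichlorophenyl in place of 2,6-dimethoxyphenyl on a carbon with a double bond to nitrogen and the rest is unchanged. Going by the values given here, the only measured step at this place is a 1.2-fold lower number from compound 1 to compound 2 (0.07 log units; within the scatter) and it involved other groups. No step beyond the scatter is therefore expected in this assay for this change. The expected step is a 1.3-fold lower number from compound 2 to compound 3 (0.10 log units; within the scatter) on this estimate. Compound 3 is expected at 10000 nM with an estimated range of 4000 nM to 25000 nM as the likely span.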

Compound 3, concentration for 50% growth inhibition: 36300 nM
Beside the measured number, compound 3's estimate is 3.6-fold (0.56 log units) below it, and the stated range ends below it.
By their numbers in this assay, from the lowest: compounds 2 and 1 (each within the scatter of the next); then compound 3.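

At this place, on a carbon with a double bond to nitrogen, this assay now responds to the group carried: 2,4-dichlorophenyl gives a 2.9-fold higher number from compound 2 to compound 3 (0.46 log units; beyond the scatter) and, set against 4-hydroxyphenyl, a 2.5-fold higher number from compound 1 to compound 3 (0.39 log units; beyond the scatter) with both steps modest. Going by these compounds alone, the two earlier groups had stayed within the scatter of each other, so this is the first step at this place to pass beyond it. Nothing measured here bears on what lies behind the change.

As far as these compounds go, whether a single chlorine or an amine on the phenyl ring would also raise the number stays open. So does whether any group at this place could bring it clearly lower than the 2,6-dimethoxyphenyl and 4-hydroxyphenyl compounds.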